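Replacing a Fluorinated Ring with a Cyano-Lactam: Expected Toxicity

This account rests on a few compounds, and the source may have more. Where it says the series, first, only, none or still open, it means among the compounds named here.

Compound 1 `O=C(Nc1cc(F)c(F)c(F)c1)N1Cc2c(-c3ccc(F)cc3F)cnn2CC1C1CC1`: 32100 nM
Compound 2 `C[C@H]1Cn2ncc(N3CC(c4ccccc4)CC3=O)c2CN1CC(=O)Nc1cc(F)c(F)c(F)c1`: > 2000 nM
Compound 3 `CC1CCn2ncc(N3CC(c4ccccc4)CC3=O)c2CN1C(=O)Nc1cc(F)c(F)c(F)c1`: > 2000 nM

Three compounds sharing a fused bicyclic core were tested in a toxicity assay on HepG2 2.2.15 cells (Homo sapiens) for cytotoxicity, read by CellTiter-Glo; on this read-out higher numbers stand for lower toxicity in this test and lower numbers for higher toxicity in this test. Among the measured compounds shown here, compound 1 is the only one with an actual number, its half-maximal cytotoxic concentration being 32100 nM. For compound 2 the result is a limit rather than a number, > 2000 nM. For compound 3 the result is likewise a limit, > 2000 nM. Thus the picture is summed up by the limit of > 2000 nM in this assay, at which 2 of the 3 values shown sit, and no step between two measured compounds can be given here.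

Compound 4 `N#CC1CC(=O)N(c2cnn3c2CN(C(=O)Nc2cc(F)c(F)c(F)c2)C(C2CC2)C3)C1` is the untested member. It differs from compound 1 in one place: 4-cyano-2-oxopyrrolidin-1-yl in place of 2,4-difluorophenyl on an aromatic carbon. Compounds 2 and 3 carry a related oxopyrrolidinyl group on that same aromatic carbon, and both stayed beyond the limit of this assay, which gives no sign of strong toxicity for that kind of group.

For compound 4, therefore, the expected outcome in this assay is low toxicity, estimated at 30000 nM with a range from 10000 nM to 90000 nM. The estimated step of a 1.1-fold lower number from compound 1 to compound 4 (0.03 log units; within the scatter) is expected to stay within the usual scatter, with a fair chance that only a limit is reported.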

Compound 4, half-maximal cytotoxic concentration: > 200000 nM
Compound 4: no number, only a limit (the forecaster's own chance of this, stated with the estimate: 40%); middle value at least 6.6-fold (0.82 log units) from the limit.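

Putting 4-cyano-2-oxopyrrolidin-1-yl in place of 2,4-difluorophenyl on this aromatic carbon gives an at least 6.2-fold higher number from compound 1 to compound 4 (0.79 log units; beyond the scatter) in this assay, so here the change moves the read-out towards lower toxicity by more than the usual scatter. Among the compounds shown here, this is the first measured step at this position, and it shows that the change does more than leave the read-out where it was. The oxopyrrolidinyl compounds 2 and 3 could not show this, as each gave only a limit and each differs from compound 1 in more than one place: the limit of > 2000 nM in this assay, at which 2 of the 4 values shown sit.

On these data alone, the step itself remains open-ended, since compound 4 also gave only a limit, and the swap changes several things at once: an aromatic ring of carbon only leaves, while a non-aromatic ring and a nitrile enter together. The compounds shown therefore cannot tell how much of the step belongs to the ring and how much to the nitrile, a question that a plain 2-oxopyrrolidin-1-yl, or the same ring carrying a carboxylic acid in place of the nitrile, would help to answer.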